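The compounds below may be only part of what the source reports. "The series", "measured", "known", "first", "only" and "open" are said of these compounds alone.

In an ADME assay on HepG2 cells (Homo sapiens) for inhibition, read by resazurin assay, with a stated time of 48 h (on this read-out lower numbers stand for an effect already at smaller amounts and higher numbers for an effect only at larger amounts of compound), compound 3 `O=C(Nc1ccc2sc(-c3ccc(F)c(F)c3)nc2c1)N1CCCC1` gives > 50 uM, which is a limit of the assay and not a number. Compound 1 `O=C(Nc1ccc2sc(-c3ccccc3F)nc2c1)N1CCCC1` gives > 50 uM, also a limit. Compound 2 `O=C(Nc1ccc2sc(-c3ccc(F)c(F)c3)nc2c1)N1CCC(F)CC1` gives > 50 uM, again a limit. Compound 4 `O=C(Nc1ccc2sc(-c3cccc(F)c3)nc2c1)N1CCCC1` differs from compound 3 in one place: hydrogen in place of fluoro on an aromatic carbon, with hydrogen in place of fluoro on an aromatic carbon, so that 3,4-difluorophenyl becomes 3-fluorophenyl. The closest measured change is a step that the two limits leave unreadable from compound 1 to compound 3, which also alters the fluoro pattern on the phenyl group. The other, a step that the two limits leave unreadable from compound 2 to compound 3, concerns the group on the carbonyl carbon. What remains to go on is the limit of > 50 uM in this assay, at which 3 of the 3 values shown sit. The expected step that the limit leaves unreadable from compound 3 to compound 4 is therefore no larger than the scatter, in no foreseeable direction. Compound 4 is estimated at 60 uM, with an expected range from 35 uM to 120 uM.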

Compound 4, concentration for 90% of the maximal effect: > 50 uM
Compound 4 ended at the assay's limit (the forecaster's own chance of this, stated with the estimate: 90%); the middle value is on the limit's open side.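

Compound 4, like compound 3 and compound 1, gives only a limit and not a number, so the steps between them cannot be read: the limit of > 50 uM in this assay, at which 4 of the 4 values shown sit. On these data alone, whether changing the fluoro pattern on the phenyl group affects this read-out at all stays open.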